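Replacing the Weinreb-type amide on the shared core of compound 1

A few compounds are considered here, and "the series" means these few. Any claim that something is new, unique, unknown or untested is made for them only; others in the source may bear on it.

The series shares the core of compound 1 `COc1ccc2c(c1)OC(c1cc(OC)c(OC)c(OC)c1)C(C(=O)N(C)OC)=C2` and varies only the group on a double-bonded ring carbon. In a functional assay for inhibition of nuclear factor NF-kappa-B complex (Homo sapiens) (a lower number here means a stronger inhibitor, a higher number a weaker inhibitor), compound 1 gives 11700 nM, the lowest of the two numbers reported. Compound 2 `CCCCNC(=O)C1=Cc2ccc(OC)cc2OC1c1cc(OC)c(OC)c(OC)c1` gives 25500 nM in this assay, and a 2.2-fold higher number from compound 1 to compound 2 (0.34 log units; beyond the scatter). Compound 3 `COc1ccc2c(c1)OC(c1cc(OC)c(OC)c(OC)c1)C(C(=O)O)=C2` gives only a limit in this assay, > 50000 nM. From that limit follows an at least 4.2-fold higher number from compound 1 to compound 3 (0.63 log units; beyond the scatter); it rests on (the limit of > 50000 nM in this assay, at which 1 of the 3 values shown sits).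

Compound 4 `COc1ccc2c(c1)OC(c1cc(OC)c(OC)c(OC)c1)C(/C=N/O)=C2` differs from compound 1 in one place: a group of 3 heavy atoms (1 carbon, 1 nitrogen, 1 oxygen; no ring) in place of a group of 6 heavy atoms (3 carbon, 1 nitrogen, 2 oxygen; no ring), on a double-bonded ring carbon. Going by the values given here, both measured steps away from the methoxy(methyl)carbamoyl of compound 1 raised the number, and the new group keeps neither the carbonyl nor the two substituents on its nitrogen, so a step of at least the size of the one from compound 1 to compound 2 is expected, with weaker inhibition. The expectation for compound 4 is therefore a 2.4-fold higher number from compound 1 to compound 4 (0.38 log units; beyond the scatter). Compound 4 is estimated at 28000 nM in this assay, within 9000 nM to 80000 nM.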

Compound 4, half-maximal inhibitory concentration: 14100 nM
Beside the measured number, compound 4's estimate is 2.0-fold (0.30 log units) above it; measured number inside the range.
By their numbers in this assay, from the lowest: compounds 1, 4 and 2 (each within the scatter of the next, the first and the last beyond it). At a limit, above all of these: compound 3.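

Going by these compounds alone, at this double-bonded ring carbon, the methoxy(methyl)carbamoyl can be replaced by a group of 3 heavy atoms with no carbonyl and no step that stands out from the scatter in this assay: a 1.2-fold higher number from compound 1 to compound 4 (0.08 log units; within the scatter). The comparison with the butylamino amide, a 1.8-fold lower number from compound 2 to compound 4 (0.26 log units; within the scatter), also lies within the scatter, so the new group cannot be ranked against either amide. The number of heavy atoms alone does not set the level here, as two groups of 3 heavy atoms are separated by an at least 3.5-fold lower number from compound 3 to compound 4 (0.54 log units; beyond the scatter), a floor that rests on a limit: the limit of > 50000 nM in this assay, at which 1 of the 4 values shown sits.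

Compound 1 gives 11700 nM, and the compounds shown leave open whether a nitrile, a primary amide or an aldehyde on this carbon would give a lower number by more than the scatter. They also leave open whether the new group's hydrogen-bond donor matters, which a methyl ether of its oxygen would test.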